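A few compounds are considered here, and "the series" means these few. Any claim that something is new, unique, unknown or untested is made for them only; others in the source may bear on it.

Measured so far:

Compound 1, `O=C(Nc1cnc(NCc2c(F)ccc3c2CCO3)n2cnnc12)c1ccccc1`: 10 mL.min-1.g-1
Compound 2, `CNC(=O)c1ncc(-c2cnc(NCc3c(F)ccc4c3CCO4)c3cn[nH]c(=O)c23)n1C`: 24 mL.min-1.g-1

The study follows two measured compounds in an ADME assay on microsomes from liver (Homo sapiens) for metabolic stability, read by LC-MS, using NADPH, with stated times of 5 min and 30 min, tested at 1 uM (a lower number here means slower removal, a higher number faster removal of the compound), and one compound still to be tested there. Compound 1 has the lowest of the two numbers in this assay, and the nearest neighbour, compound 2, gives a value a good deal higher, a gap that lies beyond the usual scatter of the method; as the two differ in more than one place, nothing more than this comparison of their values can be drawn.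

The step now taken leads from compound 1 to compound 3, `CN(c1ncco1)c1cnc(NCc2c(F)ccc3c2CCO3)n2cnnc12`. The change is:

methyl(1,3-oxazol-2-yl)amino in place of benzamido on an aromatic carbon

The benzamido group carries the only hydrogen-bond donor that leaves, and the group that enters brings a five-membered aromatic ring with two hetero atoms and no donor. For the measured compounds named here, no measured pair in the set shows such a change, so the expectation rests on compound 1 alone. The account expects compound 3 to sit close to compound 1, with a step of a 1.5-fold higher number from compound 1 to compound 3 (0.18 log units; within the scatter) that is small and, if anything, upward, not clearly beyond the scatter. Compound 3 is therefore estimated at 15 mL.min-1.g-1, within a range from 6 mL.min-1.g-1 to 40 mL.min-1.g-1.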

Compound 3, intrinsic clearance in microsomes: 11 mL.min-1.g-1
Beside the measured number, compound 3's estimate is 1.4-fold (0.13 log units) above it; measured number inside the range.
By their numbers in this assay, from the lowest: compounds 1 and 3 (each within the scatter of the next); then compound 2.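

For the compounds shown here, at this aromatic carbon, ortho to a fused ring and para to a large group, the pair gives the first reading of a single change in this assay: methyl(1,3-oxazol-2-yl)amino in place of benzamido gives a 1.1-fold higher number from compound 1 to compound 3 (0.04 log units; within the scatter). The number therefore stays within the scatter even though the six-membered aromatic ring of carbon only, the amide hydrogen and the carbonyl of benzamido all leave, and a five-membered aromatic ring with 2 hetero atoms enters, so in this one pair the exchange of these two groups leaves no reading that can be told apart in this assay. Nothing measured here accounts for this outcome, and the pair offers no explanation of its own.

The compounds shown leave open whether the same holds for groups of another kind on this carbon, such as a plain amine, a carboxylic acid or a morpholine ring, and whether the methyl on the linking nitrogen of compound 3 counts for anything, as a bare amine hydrogen there would show. They also leave open whether this result carries over to a core such as that of compound 2.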